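Compound 3 and the Step to Compound 4

A few compounds are considered here, and "the series" means these few. Any claim that something is new, unique, unknown or untested is made for them only; others in the source may bear on it.

In a functional assay on T47D cells (Homo sapiens) for inhibition, read by CCK-8 assay, with a stated time of 72 h, tested at 10 uM (a higher number here means more inhibition of growth at the concentration tested, a lower number less inhibition of growth), compound 1 (`Cc1cccc(NC(=O)C2(C(=O)Nc3ccc(Nc4ncc5cc(C(=O)N(C)C)n(C6CCCC6)c5n4)cc3)CC2)c1`) gives 95.3% and compound 2 (`CN(C)C(=O)c1cc2cnc(Nc3ccc(NC(=O)C4(C(=O)Nc5ccc(Cl)cc5)CC4)cc3)nc2n1C1CCCC1`) gives 95% at the tested concentration, with a number 0.3 percentage points lower from compound 1 to compound 2 (within the scatter) as the step between them. Compound 3 (`CN(C)C(=O)c1cc2cnc(Nc3ccc(NC(=O)C4(C(=O)Nc5cccc(F)c5)CC4)cc3)nc2n1C1CCCC1`) stands lowest of the three at -0.4% on this scale. Two large steps lead to it, a number 95.7 percentage points lower from compound 1 to compound 3 (beyond the scatter) and a number 95.4 percentage points lower from compound 2 to compound 3 (beyond the scatter) as measured. The change to compound 4 (`CN(C)C(=O)c1cc2cnc(Nc3ccc(NC(=O)C4(C(=O)Nc5ccc(Cl)c(C(F)(F)F)c5)CC4)cc3)nc2n1C1CCCC1`) is 4-chloro-3-(trifluoromethyl)phenyl in place of 3-fluorophenyl on an amide-type nitrogen and puts 4-chloro-3-(trifluoromethyl)phenyl in place of 3-fluorophenyl on an amide-type nitrogen. For the measured compounds named here, no measured compound carries this group, but the 4-chlorophenyl of compound 2, at 95% here, is the closest precedent, so a large rise is expected. The expected step is a number 85.4 percentage points higher from compound 3 to compound 4 (beyond the scatter) by this estimate. In this assay the estimate for compound 4 is 85% with an expected range from 30% to 100% overall.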

Compound 4, percent growth inhibition at one concentration: 55.8%
The estimate for compound 4 lay 29.2 percentage points above the measured number; measured number inside the range.
By their numbers in this assay, from the lowest: compound 3; then compound 4; then compounds 2 and 1 (each within the scatter of the next).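

In this assay, the 4-chloro-3-(trifluoromethyl)phenyl group on the amide-type nitrogen restores only part of the growth inhibition absent with 3-fluorophenyl (a number 56.2 percentage points higher from compound 3 to compound 4 (beyond the scatter)). Adding trifluoromethyl to the 4-chlorophenyl group is therefore not a neutral change (a number 39.2 percentage points lower from compound 2 to compound 4 (beyond the scatter)). The new group also falls short of 3-methylphenyl (a number 39.5 percentage points lower from compound 1 to compound 4 (beyond the scatter)), so a 4-chloro group does not secure the full effect in every setting. No evidence is available to explain these differences.
From the compounds shown here alone, it remains open how 4-aminophenyl or 4-carboxyphenyl would behave on this nitrogen. Going by these compounds, it also remains open whether 3-(trifluoromethyl)phenyl without the chlorine would resemble compound 3 or compound 4.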